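A few compounds are considered here, and "the series" means these few. Any claim that something is new, unique, unknown or untested is made for them only; others in the source may bear on it.

Measured in an assay on isolated protein for displacement of a labelled ligand from metabotropic glutamate receptor 5 (Homo sapiens), with a stated time of 60 min, tested at 1 uM; a higher number here means more inhibition at the concentration tested (going by the name of the read-out), a lower number less inhibition:
compound 1 `CC1CCN(c2c(S(=O)(=O)c3cc(F)cc(F)c3)cnc3cc(F)ccc23)CC1`: 77%
compound 2 `Cc1ccc2ncc(S(=O)(=O)c3ccccc3)c(N3CCC(C)CC3)c2c1`: 67%
compound 3 `Cc1ccc2ncc(S(=O)(=O)c3ccc(C#N)cc3)c(N3CCC(C)CC3)c2c1`: 55%

Compound 3 stands lowest of the three numbers in this assay. Its nearest neighbour is compound 2, which sits higher beyond the scatter, and compound 1 sits furthest above it, also beyond the scatter. For the measured compounds named here, the one step measured, a number 12 percentage points lower from compound 2 to compound 3 (beyond the scatter), is modest and downward: cyano in place of hydrogen on an aromatic carbon costs inhibition.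

Compound 4 `COc1ccc(S(=O)(=O)c2cnc3ccc(C)cc3c2N2CCC(C)CC2)cc1Cl` is not yet measured. It differs from compound 3 as follows: 3-chloro-4-methoxyphenyl in place of 4-cyanophenyl on a sulfonyl sulfur. Going by the values given here, the only step that bears on this change is a number 12 percentage points lower from compound 2 to compound 3 (beyond the scatter), and it speaks to the departing group rather than to the entering one: removing the cyano from the aryl on the sulfonyl sulfur returns the number to the level of compound 2. Compound 1 carries a differently substituted aryl on the same sulfonyl sulfur and is the highest number, but its core also differs from that of compound 3, so it gives no clean comparison. Among the compounds with values here, no measured compound carries a 3-chloro-4-methoxyphenyl, so the direction of the entering group is not covered by any step.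

The expectation for compound 4 is therefore a rise of about a number 8 percentage points higher from compound 3 to compound 4 (within the scatter) in this assay, back toward the level of compound 2. The estimate for compound 4 is 63%, with a range from 45% to 78%.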

Compound 4, a percentage reported as inhibition, at one concentration (the size of the read-out at that concentration, not a potency): 93%
Compound 4: the middle estimate sits 30 percentage points below what was measured; measured number above the stated range.
By their numbers in this assay, from the lowest: compound 3; then compounds 2 and 1 (each within the scatter of the next); then compound 4.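

In this assay, the place on the sulfonyl sulfur turns out to allow a rise as well as a fall: 3-chloro-4-methoxyphenyl in place of 4-cyanophenyl gives a number 38 percentage points higher from compound 3 to compound 4 (beyond the scatter), and 3-chloro-4-methoxyphenyl in place of phenyl gives a number 26 percentage points higher from compound 2 to compound 4 (beyond the scatter). For the compounds shown here, the second step matters more, since it shows that the gain does not merely reverse the loss seen with the cyano group: compound 4, at 93%, stands clear of the unsubstituted phenyl of compound 2, which the earlier compounds could not show. Nothing available bears on what lies behind these two steps.

The chloro and methoxy groups enter together, so the share of each in the rise remains unresolved, as does the outcome with either group alone on the aryl. Also open, from the compounds shown here alone, are the effect of an amine or a carboxylic acid on this aryl and whether 3-chloro-4-methoxyphenyl gives a similar number on the core of compound 1, while the single-concentration read-out shows only the size of the effect at that concentration and leaves the effect at other concentrations unaddressed.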